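The source may hold more compounds than are shown below. What is called first, only, known or untested is meant among the compounds shown, and "the series" means these compounds.

Compound 1 `C#CCSc1nc(Nc2ccccc2Cl)c(C#N)c(-c2ccccc2)n1`: in a functional assay on ECa-109 cells (Homo sapiens) for inhibition, read by MTT assay, with a stated time of 72 h (a higher number here means a weaker inhibitor, a lower number a stronger inhibitor), compound 1 gives only a limit, > 128000 nM.
Compound 2 `Cc1ccc(Nc2nc(SCc3cn(Cc4ccccc4Cl)nn3)nc(-c3ccccc3)c2C#N)cc1`: in this assay compound 2 likewise gives only a limit, > 64000 nM.
Compound 3 `Cc1ccc(Nc2nc(SCc3cn(Cc4ccccc4Cl)nn3)nc(-c3ccc(C)cc3)c2C#N)cc1`: in this assay compound 3 gives 4650 nM.

Going by the values given here, compound 3 therefore holds the only real number among the three; the other two sit at limits (the limit of > 128000 nM in this assay, at which 1 of the 3 values shown sits, (the limit of > 64000 nM in this assay, at which 1 of the 3 values shown sits)). Compound 4 `Cc1ccc(Nc2nc(SCc3cn(Cc4ccccc4Cl)nn3)nc(-c3ccc(Cl)cc3)c2C#N)cc1` differs from compound 3 by chloro in place of methyl on an aromatic carbon. Among the compounds with values here, the one measured step, an at least 13-fold lower number from compound 2 to compound 3 (1.13 log units; beyond the scatter), touches the same ring but swaps hydrogen for methyl, not methyl for chloro, so it gives only indirect guidance. Within the data shown here, no measured step bears on chloro against methyl, and a step within the scatter is expected, a 1.2-fold lower number from compound 3 to compound 4 (0.07 log units; within the scatter). Compound 4 is estimated at 4000 nM, between 1500 nM and 12000 nM.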

Compound 4, half-maximal inhibitory concentration: 7540 nM
Beside the measured number, compound 4's estimate is 1.9-fold (0.28 log units) below it; measured number inside the range.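

In this assay chloro in place of methyl gives a 1.6-fold higher number from compound 3 to compound 4 (0.21 log units; within the scatter) and so leaves the two groups level at this position, para to a large group. Chloro in place of hydrogen gives an at least 8.4-fold lower number from compound 2 to compound 4 (0.92 log units; beyond the scatter) as well, so the lower number in these compounds goes with more than methyl alone. That step starts from a limit, not a number: the limit of > 64000 nM in this assay, at which 1 of the 4 values shown sits. Still open, going by these compounds, is whether a methoxy group, an amine or a carboxylic acid on this carbon would give a number in the same range, and whether the same change would hold with the other groups of the shared core altered.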